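The source may hold more compounds than are shown below. What is called first, only, known or untested is meant among the compounds shown, and "the series" means these compounds.

Working notes on the nitroimidazooxazine set. Compound 1 `C[C@]1(CN2CCc3nc(-c4ccccc4)ccc3C2)Cn2cc([N+](=O)[O-])nc2O1` is the unsubstituted phenyl member. In an ADME assay on Vero cells (Chlorocebus sabaeus) for cytotoxicity, read by MTT assay, with a stated time of 72 h (on this read-out higher numbers stand for lower toxicity in this test and lower numbers for higher toxicity in this test), compound 1 gives only a limit of the assay, > 32 ug/mL. Compound 2 `C[C@]1(CN2CCc3nc(-c4ccc(Cl)cc4)ccc3C2)Cn2cc([N+](=O)[O-])nc2O1` has no result in this assay: for compound 2 the entry reads "not determined" (no result reported). Compound 3 `C[C@]1(CN2CCc3nc(-c4ccc(C#N)cc4)ccc3C2)Cn2cc([N+](=O)[O-])nc2O1` is in the same position, and in this assay compound 3 also stands at "not determined" (no result reported). So compound 3 has no single number of its own; across the three entries there is one limit and one further entry without a number, and the only read of any kind is the limit of > 32 ug/mL in this assay, at which 1 of the 3 values shown sits, at which compound 1 sits.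

The next member, compound 4 `C[C@]1(CN2CCc3nc(-c4cc(F)ccc4Cl)ccc3C2)Cn2cc([N+](=O)[O-])nc2O1`, differs from compound 3 by 2-chloro-5-fluorophenyl in place of 4-cyanophenyl on an aromatic carbon, in words 2-chloro-5-fluorophenyl in place of 4-cyanophenyl on an aromatic carbon. Going by the values given here, no measured step exists for this change, and nothing in the set points to a shift in this assay beyond the usual scatter in either direction. Compound 4 is therefore expected to read in this assay at about 40 ug/mL, between 16 ug/mL and 100 ug/mL, most likely reported again as a limit rather than a number, given that the one read in the series is the limit of > 32 ug/mL in this assay, at which 1 of the 3 values shown sits.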

Compound 4, half-maximal cytotoxic concentration: > 32 ug/mL
Compound 4 gave a limit, no number (the forecaster's own chance of this, stated with the estimate: 70%); the middle value is on the limit's open side.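

Going by these compounds alone, compound 1 and compound 4 each stand only as a limit in this assay, and no step between them can be read. The compounds shown leave open where any of them would read as a single number in this assay, and whether changing the phenyl group on the shared core moves that read at all.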